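From 3-(diethylamino)propyl to 4-(diethylamino)butyl

The source may hold more compounds than are shown below. What is called first, only, known or untested is meant among the compounds shown, and "the series" means these compounds.

In a functional assay on HL-60 cells (Homo sapiens) for antiproliferative activity, read by MTT assay, with a stated time of 48 h (a higher number here means a weaker inhibitor, a lower number a stronger inhibitor), compound 3 `CCN(CC)CCCn1c(N)c(-c2nc3cc(Cl)ccc3[nH]2)c2nc(C#N)c(C#N)nc21` gives 3470 nM, the higher of the two exact numbers available. Compound 1 `CCN(CC)CCCCn1c(N)c(-c2nc3ccccc3o2)c2nc(C#N)c(C#N)nc21` stands lower at 450 nM, a gap beyond the scatter, and it carries the 4-(diethylamino)butyl chain on a core that differs from that of compound 3. Compound 2 `CN(C)CCn1c(N)c(-c2nc3cc(Cl)ccc3[nH]2)c2nc(C#N)c(C#N)nc21` reaches only a limit of the assay, > 50000 nM. Among the compounds with values here, the one measured step, an at least 14-fold lower number from compound 2 to compound 3 (1.15 log units; beyond the scatter), is large and rests on that limit; it sets (diethylamino)methyl in place of dimethylamino, two bonds along the chain from an aromatic nitrogen. Compound 4 `CCN(CC)CCCCn1c(N)c(-c2nc3cc(Cl)ccc3[nH]2)c2nc(C#N)c(C#N)nc21` takes the chain one stage further, from 3-(diethylamino)propyl to 4-(diethylamino)butyl ((diethylamino)methyl in place of diethylamino on a saturated chain carbon, three bonds along the chain from an aromatic nitrogen). This is not the same change as in the measured step, so that step offers only a direction, and the lower value of compound 1 points the same way. The expected step is a 2.7-fold lower number from compound 3 to compound 4 (0.43 log units; beyond the scatter), in that direction but smaller than the measured one. Compound 4 is estimated at 1300 nM, with an expected range from 350 nM to 4500 nM.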

Compound 4, half-maximal inhibitory concentration: 820 nM
Beside the measured number, compound 4's estimate is 1.6-fold (0.20 log units) above it; the range from low to high includes it.
By their numbers in this assay, from the lowest: compounds 1 and 4 (each within the scatter of the next); then compound 3. At a limit, above all of these: compound 2.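

In this assay, within the data shown here, the chain extension from 3-(diethylamino)propyl to 4-(diethylamino)butyl gives a 4.2-fold lower number from compound 3 to compound 4 (0.63 log units; beyond the scatter), the first measured step at this place with the diethylamino end kept, and so a size for a change that earlier had only a direction. With the 4-(diethylamino)butyl chain in both compounds, the swap on an aromatic carbon to 5-chloro-1H-benzimidazol-2-yl from 1,3-benzoxazol-2-yl gives a 1.8-fold higher number from compound 1 to compound 4 (0.26 log units; within the scatter), so these two groups are not told apart here. The widest step, an at least 60-fold lower number from compound 2 to compound 4 (1.78 log units; beyond the scatter), starts from a limit of the assay and has no exact size: the limit of > 50000 nM in this assay, at which 1 of the 4 values shown sits.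

As far as these compounds go, whether a longer chain, such as 5-(diethylamino)pentyl, continues this direction remains open. So does the effect of a piperidine in place of the diethylamino group on the 4-carbon chain.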